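This account rests on a few compounds, and the source may have more. Where it says the series, first, only, none or still open, it means among the compounds named here.

Measured compounds:

- compound 1, `COc1ccc(/C=C/C(=O)O)cc1OC(=O)c1nc(C)c(C)nc1C`: in a functional assay on EA.hy 926 cells (Homo sapiens) for cytotoxicity, read by MTT assay, with stated times of 24 h and 12 h (on this read-out lower numbers stand for an effect already at smaller amounts and higher numbers for an effect only at larger amounts of compound), compound 1 gives 8800 nM
- compound 2, `CCOC(=O)/C=C/c1cc(OC)c(OC(=O)c2nc(C)c(C)nc2C)c(OC)c1`: in this assay compound 2 gives 21400 nM
- compound 3, `Cc1nc(C)c(C(=O)Oc2cccc(/C=C/C(=O)O)c2)nc1C`: in this assay compound 3 gives 24000 nM

Compound 1 and compound 2 carry different cores; the difference between the two cores is not broken down here. Compound 3 derives from compound 1 by one change, (hydrogen in place of methoxy on an aromatic carbon), and in this assay this gave a 2.7-fold higher number from compound 1 to compound 3 (0.44 log units; beyond the scatter). Compound 2 stands close to compound 3, within the usual scatter, and apart from compound 1, beyond it.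

Compound 4, `CCOC(=O)/C=C/c1ccc(OC(=O)c2nc(C)c(C)nc2C)c(OC)c1`, is not yet measured. It derives from compound 2 by hydrogen in place of methoxy on an aromatic carbon. For the measured compounds named here, this is the same kind of change as the one from compound 1 to compound 3, not the same change: in compound 1 the leaving methoxy sits ortho to a large group and para to a 2-carboxyethenyl group, whereas in compound 2 it sits ortho to a large group, meta to a 2-(ethoxycarbonyl)ethenyl group and meta to a methoxy group. Going by the values given here, only one measured example of this change exists, so the expectation rests on a single step.

The expected step from compound 2 to compound 4 in this assay is a 1.9-fold higher number from compound 2 to compound 4 (0.27 log units; within the scatter), in the same direction as the measured 2.7-fold higher number from compound 1 to compound 3 (0.44 log units; beyond the scatter) but held more loosely. The surroundings of the change differ between the two pairs, and the expectation is held loosely for that reason. Compound 4 is expected to give an estimate of 40000 nM, with a range from 15000 nM to 100000 nM.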

Compound 4, half-maximal effective concentration: 38600 nM
Beside the measured number, compound 4's estimate is 1.0-fold (0.02 log units) above it; measured number inside the range.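

On the core of compound 2, hydrogen in place of methoxy gives a 1.8-fold higher number from compound 2 to compound 4 (0.26 log units; within the scatter) and so does not clearly separate the two compounds in this assay. Set beside the earlier step, the change shows no detectable difference in size between the two cores: the same change on two cores in this assay, a 2.7-fold higher number (0.44 log units; beyond the scatter) from compound 1 to compound 3 and a 1.8-fold higher number (0.26 log units; within the scatter) from compound 2 to compound 4, 1.5-fold (0.18 log units) apart, within the scatter of two such steps. For the compounds shown here, this supports carrying the change between these two cores as a rough expectation, but it rests on only two pairs, and since the second step stays within the scatter, it does not show that removing methoxy has a real effect on the core of compound 2 or that the change would behave alike on any further core.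

Still open, as far as these compounds go, is how other groups at the same place, ortho to a large group, would compare with methoxy and hydrogen, for example a hydroxy group, a chlorine atom or a longer alkoxy chain such as propoxy. Also open, from the compounds shown here alone, is how the series would respond if an amide link replaced the ester link that carries the methoxy-bearing ring, or if an amine stood at the end of the ethenyl chain.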